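Extending an Ester Chain Where Cytotoxicity Sits at the Limit

This account rests on a few compounds, and the source may have more. Where it says the series, first, only, none or still open, it means among the compounds named here.

Compound 1, `CCOS(=O)(=O)/C=C/c1ccc(OCc2ccccc2)cc1OCCc1nc(-c2ccccc2)oc1C`, a limit in an ADME assay on COS-7 cells (Chlorocebus aethiops) for cytotoxicity, read by MTT assay, with a stated time of 48 h; on this read-out lower numbers stand for stronger inhibition and higher numbers for weaker inhibition: > 100000 nM
Compound 2, `CCOS(=O)(=O)/C=C/c1ccc(OCc2ccccc2)cc1OCCc1csc(-c2ccccc2)n1`, a limit in this assay: > 100000 nM
Compound 3, `COS(=O)(=O)/C=C/c1ccc(OCc2ccccc2)cc1OCCc1nc(-c2ccccc2)oc1C`, a limit in this assay: > 100000 nM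

Every value here is a limit, not a number, since (the limit of > 100000 nM in this assay, at which 3 of the 3 values shown sit). Compound 3 therefore stands at the same limit as the other two, and nothing separates them on the numbers shown. The two measured steps, a step that the two limits leave unreadable from compound 1 to compound 2 and a step that the two limits leave unreadable from compound 1 to compound 3, cannot be read for size or direction, because both ends sit at the limit of > 100000 nM in this assay, at which 3 of the 3 values shown sit.

Compound 4, `CCCCOS(=O)(=O)/C=C/c1ccc(OCc2ccccc2)cc1OCCc1nc(-c2ccccc2)oc1C`, carries the change (propyl in place of hydrogen on a saturated chain carbon bound to an oxygen on an unsaturated carbon). For the measured compounds named here, no measured step bears on it in a readable way; the only chain variation recorded, from compound 1 to compound 3, is itself unreadable. The expected outcome for compound 4 is that this assay again reports a limit rather than a number, so the step is estimated as a step that the limit leaves unreadable from compound 3 to compound 4, none beyond the scatter. Compound 4 is accordingly estimated at 150000 nM, with a range from 50000 nM to 500000 nM.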

Compound 4, half-maximal inhibitory concentration: > 100000 nM
Compound 4 ended at the assay's limit (the forecaster's own chance of this, stated with the estimate: 85%); the middle value is on the limit's open side.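

No new step can be read from compound 3 to compound 4 or from compound 1 to compound 4, because all these values are limits, not numbers: (the limit of > 100000 nM in this assay, at which 4 of the 4 values shown sit). In this assay the compounds shown leave open whether going from methoxy to butoxy, or any other change here, alters cytotoxicity at all.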